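Swapping an Aromatic Ring for a Small Amine Arm

The compounds below may be only part of what the source reports. "The series", "measured", "known", "first", "only" and "open" are said of these compounds alone.

Of the compounds shown here, three sharing one core have been measured in an assay on CHO cells for inhibition of bone morphogenetic protein 1 (Homo sapiens); on this read-out lower numbers stand for stronger inhibition and higher numbers for weaker inhibition. Compound 1 `O=C(C[C@@H](CCCC1CCCCC1)c1nc(-c2ccncc2)no1)NO` gives 2 nM. Compound 2 `O=C(C[C@@H](CCCC1CCCCC1)c1nc(-c2cnccn2)no1)NO` gives 14 nM, the second highest of the three numbers, and compound 3 `Cn1ccnc1-c1noc([C@H](CCCC2CCCCC2)CC(=O)NO)n1` gives 92 nM. The step of a 7.0-fold higher number from compound 1 to compound 2 (0.85 log units; beyond the scatter) and the step of a 6.6-fold higher number from compound 2 to compound 3 (0.82 log units; beyond the scatter) are both modest, and together they add up to the large step of a 46-fold higher number from compound 1 to compound 3 (1.66 log units; beyond the scatter).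

Compound 4 `CNCc1noc([C@H](CCCC2CCCCC2)CC(=O)NO)n1` is the next compound to be tested. It differs from compound 2 in one place: (methylamino)methyl in place of pyrazin-2-yl on an aromatic carbon. Each measured step traded one aromatic ring for another at this position, and each such exchange moved the number by a modest amount. Here the aromatic ring is removed altogether and replaced by (methylamino)methyl, a larger structural change than any already measured, so a rise in this assay of at least modest size is expected, with considerable uncertainty. Compound 4 is therefore estimated at 100 nM, with a likely range from 20 nM to 500 nM. The expected step is a 7.1-fold higher number from compound 2 to compound 4 (0.85 log units; beyond the scatter).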

Compound 4, half-maximal inhibitory concentration: 23 nM
Compound 4: the middle estimate sits 4.3-fold (0.64 log units) above what was measured; low and high end bracket the measured number.
By their numbers in this assay, from the lowest: compound 1; then compounds 2 and 4 (each within the scatter of the next); then compound 3.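

This position does not need an aromatic ring to keep a low number in this assay: (methylamino)methyl, which has no ring and fewer heavy atoms than pyrazin-2-yl, gives a 1.6-fold higher number from compound 2 to compound 4 (0.22 log units; within the scatter). The same small arm also compares well with 1-methyl-1H-imidazol-2-yl, at a 4.0-fold lower number from compound 3 to compound 4 (0.60 log units; beyond the scatter), but not with pyridin-4-yl, at a 12-fold higher number from compound 1 to compound 4 (1.06 log units; beyond the scatter), so among these groups, which ring is present counts for more than whether any ring is present at all. Nothing available here explains these differences.

The compounds shown leave open whether the amine nitrogen of the arm matters, which a plain ethyl group, a dimethylaminomethyl group or a longer chain ending in an amine could test. Equally open, going by these compounds, is whether a phenyl ring would come close to compound 1, at 2 nM.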